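Swapping Amino for Phenyl on a Carbonyl Carbon

The source may report more compounds than this note shows. Statements on the series, on what has been measured and on what is new or still open speak of the compounds shown alone.

Within the data shown here, compound 2 `COc1ccc(-c2nc(SCc3ccccc3)nc(N3CCC(C(N)=O)CC3)c2C#N)cc1` has the larger of the two numbers measured so far, but the gap to compound 1 `N#Cc1c(-c2ccc(Cl)cc2)nc(SCc2ccccc2)nc1N1CCC(C(=O)c2ccccc2)CC1` lies within the usual scatter, so the two cannot be told apart. In an ADME assay on Jurkat cells (Homo sapiens) for inhibition, read by WST assay, with a stated time of 48 h, tested at 10 uM (a higher number here means more inhibition at the concentration tested (going by the name of the read-out), a lower number less inhibition), compound 2 gives 12% and compound 1 gives 6%. Compound 3 `COc1ccc(-c2nc(SCc3ccccc3)nc(N3CCC(C(=O)c4ccccc4)CC3)c2C#N)cc1` differs from compound 2 in one place: phenyl in place of amino on a carbonyl carbon. Compound 1 already carries a benzoyl group and gives 6% in this assay. The step from compound 2 to compound 3 is therefore expected to stay within the scatter, estimated as a number 4 percentage points lower from compound 2 to compound 3 (within the scatter). Compound 3 is expected to give about 8%, between 0% and 22%.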

Compound 3, a percentage reported as inhibition, at one concentration (the size of the read-out at that concentration, not a potency): 2%
Compound 3: middle estimate off by 6 percentage points, on the high side; measured number inside the range.
By their numbers in this assay, from the lowest: compounds 3, 1 and 2 (each within the scatter of the next).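

Phenyl in place of amino on the carbonyl carbon gives a number 10 percentage points lower from compound 2 to compound 3 (within the scatter) in this assay and so shows no readable change, even though a whole aromatic ring replaces a single nitrogen and the amide hydrogen is lost. Methoxy in place of chloro on an aromatic carbon, with the benzoyl group kept, gives a number 4 percentage points lower from compound 1 to compound 3 (within the scatter) and likewise shows no readable change. Nothing measured here offers an explanation for either step.

As far as these compounds go, it remains open whether a longer alkyl chain on this carbonyl carbon would move the number beyond the scatter. The same question stands for an amine in place of methoxy on the aromatic carbon.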